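This account rests on a few compounds, and the source may have more. Where it says the series, first, only, none or still open, it means among the compounds named here.

Measured so far:
- Compound 1, `O=C(Nc1ccccc1)C(Cl)Cl`, 130000 nM
- Compound 2, `O=C(Nc1cccc(F)c1)C(Cl)Cl`, "not determined" (no result reported)
- Compound 3, `O=C(Nc1cccc(Br)c1)C(Cl)Cl`, 7800 nM

In a functional assay on A549 cells (Homo sapiens) for antiproliferative activity, read by MTT assay, with a stated time of 72 h (a higher number here means a weaker inhibitor, a lower number a stronger inhibitor), compound 3 holds the lowest number of the two reported, and the gap to compound 1 is large: a 17-fold lower number from compound 1 to compound 3 (1.22 log units; beyond the scatter). Compound 2 gave no number in this assay.

Compound 4, `O=C(Nc1cccc(I)c1)C(Cl)Cl`, differs from compound 3 by iodo in place of bromo on an aromatic carbon. Among the measured compounds shown here, the only step that bears on it is the one from compound 1 to compound 3, which swapped hydrogen for a halogen and was large; the swap here is between two halogens, so a far smaller step is expected in this assay, if any, with a slight lean toward a lower number. The estimate for compound 4 is 6000 nM, in the range 2500 nM to 15000 nM, a step of a 1.3-fold lower number from compound 3 to compound 4 (0.11 log units; within the scatter).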

Compound 4, half-maximal inhibitory concentration: 4760 nM
The estimate for compound 4 lay 1.3-fold (0.10 log units) above the measured number; the range from low to high includes it.
By their numbers in this assay, from the lowest: compounds 4 and 3 (each within the scatter of the next); then compound 1.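

At this aromatic carbon, iodo and bromo cannot be told apart in this assay (a 1.6-fold lower number from compound 3 to compound 4 (0.21 log units; within the scatter)), so the exchange of one of these halogens for the other leaves the number within the scatter. Iodo also stands far from hydrogen (a 27-fold lower number from compound 1 to compound 4 (1.44 log units; beyond the scatter)), so the large step seen with bromo appears with a second halogen. Nothing available explains these numbers.

Still open, on these data alone, is whether a group other than a halogen on this same carbon, such as methyl, methoxy or an amine, would give a similar step from compound 1.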